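The source may report more compounds than this note shows. Statements on the series, on what has been measured and on what is new or still open speak of the compounds shown alone.

Measured compounds:
Compound 1 `CC(=O)Nc1ccc(-c2nc3cc(C(F)(F)F)ccc3n2C2CCCCC2)cc1` gives 15000 nM in an ADME assay on BHK cells (Mesocricetus auratus) for cytotoxicity, read by MTT assay, with a stated time of 96 h; a lower number here means that less compound is tolerated, a higher number that more compound is tolerated.
Compound 2 `CC(=O)Nc1ccc(-c2nc3cc(C(F)(F)F)ccc3[nH]2)cc1` gives 53000 nM in this assay.

Compound 2 stands highest of the two numbers in this assay; its nearest neighbour is compound 1, and the step of a 3.5-fold higher number from compound 1 to compound 2 (0.55 log units; beyond the scatter) is modest but beyond the scatter. That single step concerns a hydrogen in place of cyclohexyl on an aromatic nitrogen and nothing else.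

Compound 3 `COc1ccc(-c2nc3cc(C(F)(F)F)ccc3[nH]2)cc1` is not yet measured in this assay. It differs from compound 2 in one place: methoxy in place of acetamido on an aromatic carbon. Among the measured compounds shown here, the aromatic nitrogen carries hydrogen in both compounds, so the one measured step does not bear on this change. For the measured compounds named here, no measured pair shows what an exchange of acetamido for methoxy does here, and the data give no ground for a direction. Compound 3 is therefore expected to stay near compound 2, with a step of a 1.1-fold lower number from compound 2 to compound 3 (0.03 log units; within the scatter) that is estimated to lie within the scatter. The estimate for compound 3 in this assay is 50000 nM, with a range from 18000 nM to 140000 nM.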

Compound 3, half-maximal cytotoxic concentration: > 100000 nM
Compound 3: a limit, no number; the forecaster's own chance of this, stated with the estimate: 20%; at least 2.0-fold (0.30 log units) between middle value and limit.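

Until now the group on this aromatic carbon, para to a large group, had stayed acetamido, and the only step shown concerned the aromatic nitrogen, so compound 3 gives the first view of a change at this place. With methoxy in place of acetamido, which takes away the hydrogen-bond donor and two of the heavy atoms of the group that leaves, the step in this assay reads an at least 1.8-fold higher number from compound 2 to compound 3 (0.27 log units; that floor lies within the scatter), so the exchange shows no sign of a lower number, although its floor alone does not separate the two compounds. In this assay compound 3 gives > 100000 nM, which is a limit of the assay and not a number, so only a floor can be read for this step: the limit of > 100000 nM in this assay, at which 1 of the 3 values shown sits.

The compounds shown leave open how far the true value of compound 3 lies from this limit, and whether an amine or a hydroxyl group on the same aromatic carbon would behave as methoxy does. They also leave open whether cyclohexyl on the aromatic nitrogen would give the same step with methoxy on the aromatic carbon as it does with acetamido.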